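Trimethoxyphenyl to trifluorophenyl in the naphthoquinone-derived amidine series

The compounds below may be only part of what the source reports. "The series", "measured", "known", "first", "only" and "open" are said of these compounds alone.

Three analogues of the shared core have been measured in a functional assay on A549 cells (Homo sapiens) for cytotoxicity, read by MTT assay, with a stated time of 48 h; a lower number here means a stronger inhibitor, a higher number a weaker inhibitor. Compound 1 `COc1ccc(N/C(CCNC2=CC(=O)c3ccccc3C2=O)=N\S(=O)(=O)c2ccc(C)cc2)cc1` gives 25500 nM, compound 2 `Cc1ccc(S(=O)(=O)/N=C(/CCNC2=CC(=O)c3ccccc3C2=O)Nc2ccc(Cl)cc2)cc1` gives 29900 nM, and compound 3 `COc1cc(N/C(CCNC2=CC(=O)c3ccccc3C2=O)=N\S(=O)(=O)c2ccc(C)cc2)cc(OC)c1OC` gives 7940 nM, the lowest number of the three and beyond the scatter from both: a 3.2-fold lower number from compound 1 to compound 3 (0.51 log units; beyond the scatter), a 3.8-fold lower number from compound 2 to compound 3 (0.58 log units; beyond the scatter). Compound 4 `Cc1ccc(S(=O)(=O)/N=C(/CCNC2=CC(=O)c3ccccc3C2=O)Nc2cc(F)c(F)c(F)c2)cc1` carries the change (3,4,5-trifluorophenyl in place of 3,4,5-trimethoxyphenyl on an amine nitrogen). Among the compounds with values here, no measured step exchanges methoxy for fluorine; the closest, a 1.2-fold higher number from compound 1 to compound 2 (0.07 log units; within the scatter), shows little movement. Because a 3.2-fold lower number from compound 1 to compound 3 (0.51 log units; beyond the scatter) and a 3.8-fold lower number from compound 2 to compound 3 (0.58 log units; beyond the scatter) both point to the trimethoxy group as the source of the gain, its loss is expected to cost part of that gain: a 2.0-fold higher number from compound 3 to compound 4 (0.30 log units; within the scatter). For compound 4 the estimate in this assay is 16000 nM, range 6000 nM to 40000 nM.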

Compound 4, half-maximal inhibitory concentration: 10200 nM
The estimate for compound 4 lay 1.6-fold (0.20 log units) above the measured number; low and high end bracket the measured number.
By their numbers in this assay, from the lowest: compounds 3 and 4 (each within the scatter of the next); then compounds 1 and 2 (each within the scatter of the next).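

Exchanging the 3,4,5-trimethoxyphenyl group for 3,4,5-trifluorophenyl on this amine nitrogen gives no change beyond the scatter (a 1.3-fold higher number from compound 3 to compound 4 (0.11 log units; within the scatter)), so the methoxy groups are not required for the lower number in this pair. The lower number relative to the 4-chlorophenyl and 4-methoxyphenyl groups also persists with the trifluorophenyl group (a 2.9-fold lower number from compound 2 to compound 4 (0.47 log units; beyond the scatter); a 2.5-fold lower number from compound 1 to compound 4 (0.40 log units; beyond the scatter)). No supporting measurement accounts for these numbers.

As far as these compounds go, whether a trifluoromethyl or nitrile group on this aromatic ring would keep them stays open. Behaviour outside this one cell line also remains unknown.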